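The compounds below may be only part of what the source reports. "The series", "measured", "known", "first", "only" and "open" are said of these compounds alone.

Measured in a functional assay on SW-620 cells (Homo sapiens); a higher number here means a weaker inhibitor of growth, a lower number a stronger inhibitor of growth:
- Compound 1 `O=S(=O)(/C=C/c1ccccc1)Cc1ccc(Nc2ncnc3ccccc23)cc1`: > 100000 nM
- Compound 2 `O=S(=O)(/C=C/c1ccc(Cl)cc1Cl)Cc1ccc(Nc2ncnc3ccccc23)cc1`: 14000 nM
- Compound 3 `O=S(=O)(/C=C/c1ccc(F)cc1F)Cc1ccc(Nc2ncnc3ccccc23)cc1`: 86000 nM

The entry for compound 1 is a limit of the assay, not a number. Of the two exact values, the higher belongs to compound 3, with compound 2 lower by a margin beyond the scatter: a 6.1-fold higher number from compound 2 to compound 3 (0.79 log units; beyond the scatter).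

Compound 4 `O=S(=O)(/C=C/c1ccc(F)cc1Cl)Cc1ccc(Nc2ncnc3ccccc23)cc1` turns the 2,4-difluorophenyl of compound 3 into 2-chloro-4-fluorophenyl, with chloro in place of fluoro on an aromatic carbon, ortho to a large group (chloro in place of fluoro on an aromatic carbon). The nearest evidence is the step that exchanges both chloro groups for fluoro, a 6.1-fold higher number from compound 2 to compound 3 (0.79 log units; beyond the scatter). The step of an at least 7.1-fold lower number from compound 1 to compound 2 (0.85 log units; beyond the scatter) points the same way, whereas an at least 1.1-fold lower number from compound 1 to compound 3 (0.06 log units; that floor lies within the scatter) has a floor within the scatter. Compound 4 carries only one of the two chloro groups of compound 2, so a partial move toward a lower number is expected in this assay. The expected step is a 2.5-fold lower number from compound 3 to compound 4 (0.39 log units; beyond the scatter). For compound 4 the estimated value is 35000 nM, with an expected range of 12000 nM to 90000 nM.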

Compound 4, concentration for 50% growth inhibition: 100000 nM
Estimate against measurement, compound 4: 2.9-fold (0.46 log units) below; measured number outside the range, above it.
By their numbers in this assay, from the lowest: compound 2; then compounds 3 and 4 (each within the scatter of the next).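

In this assay, chloro in place of fluoro on the aromatic carbon ortho to a large group leaves the number within the scatter: a 1.2-fold higher number from compound 3 to compound 4 (0.07 log units; within the scatter). Fluoro in place of the other chloro of compound 2 is a different matter, with a step beyond the scatter: a 7.1-fold higher number from compound 2 to compound 4 (0.85 log units; beyond the scatter). The remaining step cannot be read for its size: a number no higher from compound 1 to compound 4 (the limit leaves the size open). Compound 1 stands at a limit of the assay, not a number: the limit of > 100000 nM in this assay, at which 1 of the 4 values shown sits.

The compounds shown leave open whether chloro at the other position, without chloro at this one, is enough to give the lower number of compound 2. They also leave open whether a bromo or a methoxy group at this ortho position would move the number at all.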